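One hydroxy fewer: what to expect of compound 3

A few compounds are considered here, and "the series" means these few. Any claim that something is new, unique, unknown or untested is made for them only; others in the source may bear on it.

In a functional assay on HSC-2 cells (Homo sapiens) for cytotoxicity, read by MTT assay (on this read-out lower numbers stand for stronger inhibition and higher numbers for weaker inhibition), compound 1 (`OC[C@H]1O[C@@H](O[C@H](CCc2ccc(O)c(O)c2)C[C@H](O)CCc2ccc(O)cc2)[C@H](O)[C@@H](O)[C@@H]1O`) gives 158 ug/mL and compound 2 (`OC[C@H]1O[C@@H](O[C@H](CCc2ccc(O)c(O)c2)C[C@H](O)CCc2ccc(O)c(O)c2)[C@H](O)[C@@H](O)[C@@H]1O`) gives 92 ug/mL. Among the measured compounds shown here, these two numbers lie within the scatter of each other, so compound 1 sits level with the only other measured compound. The next compound to be tested is compound 3 (`OC[C@H]1O[C@@H](O[C@H](CCc2ccc(O)cc2)C[C@H](O)CCc2ccc(O)cc2)[C@H](O)[C@@H](O)[C@@H]1O`), which departs from compound 1 as follows: hydrogen in place of hydroxy on an aromatic carbon. This places hydrogen in place of hydroxy on an aromatic carbon, turning a 3,4-dihydroxyphenyl into a 4-hydroxyphenyl.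

For the measured compounds named here, only one measured step bears on this. It is the opposite swap, hydroxy in place of hydrogen, made on a different aromatic ring, and it gave a 1.7-fold lower number from compound 1 to compound 2 (0.23 log units; within the scatter). Going by the values given here, that single step offers weak guidance, and no measured pair shows the removal itself. A small drift towards a higher number in this assay is expected, with nothing beyond the scatter. The estimated step is a 1.2-fold higher number from compound 1 to compound 3 (0.08 log units; within the scatter). For compound 3 the expected value is 190 ug/mL, with an estimated range of 100 ug/mL to 350 ug/mL.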

Compound 3, half-maximal inhibitory concentration: 157 ug/mL
For compound 3 the middle estimate is 1.2-fold (0.08 log units) above the measured one; low and high end bracket the measured number.
By their numbers in this assay, from the lowest: compounds 2, 3 and 1 (each within the scatter of the next).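

In this assay, among the compounds shown here, the change from 3,4-dihydroxyphenyl to 4-hydroxyphenyl gives a 1.0-fold lower number from compound 1 to compound 3 (0.00 log units; within the scatter) and so supplies the first direct reading at this position, where earlier there was only the opposite swap on a different aromatic ring. With hydrogen in place of this hydroxy, on an aromatic carbon ortho to a hydroxy group and meta to a large group, compound 3 stands level with compound 1, so this one hydroxy is not needed to keep the number where it is in this assay. Nothing at hand explains why the number stays level.

What the compounds shown leave open is whether a different group on this carbon, such as a methoxy, a fluorine or an amine, would carry the number beyond the scatter. They also do not tell whether taking away the hydroxy that remains in the 4-hydroxyphenyl, leaving a plain phenyl, would change anything, or whether the same result would hold on a different core.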